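Bromo to iodo, with every value at a limit

The source may hold more compounds than are shown below. What is called first, only, known or untested is meant among the compounds shown, and "the series" means these compounds.

Compound 1 `Cc1cc(-c2nc3ccccc3s2)ccc1N` gives < 1 nM
Compound 2 `Nc1ccc(-c2nc3ccccc3s2)cc1Cl` gives < 1 nM
Compound 3 `Nc1ccc(-c2nc3ccccc3s2)cc1Br` gives < 1 nM

In a functional assay on MCF7 cells (Homo sapiens) for antiproliferative activity (on this read-out lower numbers stand for stronger inhibition and higher numbers for weaker inhibition), compound 3 stands at < 1 nM as a limit of the assay and not a number. The entries for compound 1 and compound 2 are limits too, so the record so far is the limit of < 1 nM in this assay, at which 3 of the 3 values shown sit, and nothing finer.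

Compound 4 `Nc1ccc(-c2nc3ccccc3s2)cc1I` carries one change from compound 3. The change iodo in place of bromo on an aromatic carbon sits on an aromatic carbon, ortho to an amino group. The closest measured change is a step that the two limits leave unreadable from compound 2 to compound 3 while a step that the two limits leave unreadable from compound 1 to compound 2 and a step that the two limits leave unreadable from compound 1 to compound 3 add no readable size either.

The limit that compound 3 holds is < 1 nM. No step beyond the usual scatter is expected in either direction from that limit, and another limit is the likeliest report. The expected size is a step that the limit leaves unreadable from compound 3 to compound 4 as an estimate only. Compound 4 is expected at 0.5 nM with an estimated range from 0.1 nM to 3 nM.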

Compound 4, half-maximal inhibitory concentration: < 1 nM
Compound 4: no number, only a limit; the forecaster's own chance of this, stated with the estimate: 80%; the middle value lies beyond the limit too.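

In this assay compound 4 gives < 1 nM, a limit of the assay and not a number, so no step linking it to compound 1, compound 2 or compound 3 can be read: the limit of < 1 nM in this assay, at which 4 of the 4 values shown sit.

The compounds shown leave open whether these four differ in strength at all, and by how much.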